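Imidazolyl for methylpyridinyl on the cyclic urea nitrogen

The source may report more compounds than this note shows. Statements on the series, on what has been measured and on what is new or still open speak of the compounds shown alone.

compound 1: `CN1C(=O)C(C)(C)C[C@H]1C(=O)NCc1cccc(C(F)(F)F)c1Cl`, 25.1 nM
compound 2: `Cc1cccc(N2C[C@@H](C(=O)NCc3cccc(C(F)(F)F)c3Cl)N(C)C2=O)n1`, 79.4 nM

In a functional assay on HEK293 cells for antagonist activity at P2X purinoceptor 7 (Homo sapiens) (a higher number here means a weaker inhibitor, a lower number a stronger inhibitor), compound 1 gives 25.1 nM. Compound 2 gives 79.4 nM in this assay, the higher of the two numbers; the gap to compound 1 is beyond the scatter. Among the compounds with values here, no pair of measured compounds differs in a single place, so no measured step is at hand for this change. Compound 3, `CN1C(=O)N(c2cn(C)cn2)C[C@H]1C(=O)NCc1cccc(C(F)(F)F)c1Cl`, differs from compound 2 by 1-methyl-1H-imidazol-4-yl in place of 6-methylpyridin-2-yl on an amide-type nitrogen in a ring. The amide part and the methyl on the ring nitrogen are kept; only the aromatic group on the other ring nitrogen changes. With compound 1 and compound 2 as the sole reference points, the expected step is a 1.3-fold higher number from compound 2 to compound 3 (0.10 log units; within the scatter), that is, no step beyond the scatter. Compound 3 is therefore expected near 100 nM, with a range from 30 nM to 400 nM.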

Compound 3, half-maximal inhibitory concentration: 2.51 nM
The estimate for compound 3 lay 40-fold (1.60 log units) above the measured number; measured number below the stated range.
By their numbers in this assay, from the lowest: compound 3; then compound 1; then compound 2.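

In this assay the aromatic group on this amide-type nitrogen in a ring proves a strong lever: 1-methyl-1H-imidazol-4-yl in place of 6-methylpyridin-2-yl gives a 32-fold lower number from compound 2 to compound 3 (1.50 log units; beyond the scatter) with the amide part and the methyl on the ring nitrogen kept. This single-place change shows that the number at this position depends heavily on which aromatic group is attached, and that the five-membered aromatic ring with 2 hetero atoms is far preferred here over the six-membered aromatic ring with 1 hetero atom. Nothing measured alongside these values accounts for the step.

The change alters ring size and hetero atom count together, so the compounds shown do not separate the contribution of each. On these data alone, how a 1-methyl-1H-pyrazol-4-yl group or a plain phenyl group would read at this position remains open.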